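The source may hold more compounds than are shown below. What is called first, only, known or untested is meant among the compounds shown, and "the series" means these compounds.

Measured so far:
compound 1 `O=C(c1c[nH]c(=O)c2ccccc12)N1CCN(C(=O)c2ccc(Br)cc2)[C@@H](c2ccc(Cl)cc2)C1`: 11 ug/mL
compound 2 `O=C(c1cncc2ccccc12)N1CCN(C(=O)c2ccc(Br)cc2)[C@@H](c2ccc(Cl)cc2)C1`: 5.1 ug/mL
compound 3 `O=C(c1cnn2cc(Br)ccc12)N1CCN(C(=O)c2ccc(Br)cn2)[C@@H](c2ccc(Cl)cc2)C1`: 3.8 ug/mL

All three were tested in a physicochemical assay for solubility, at pH 6.8; a higher number here means a more soluble compound, a lower number a less soluble compound. In this test compound 2 gives 5.1 ug/mL and compound 3 gives 3.8 ug/mL, two values within the usual scatter of each other. Compound 1 stands clearly higher, at 11 ug/mL.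

The next compound to be tested is compound 4 `O=C(c1ccnc2ccccc12)N1CCN(C(=O)c2ccc(Br)cc2)[C@@H](c2ccc(Cl)cc2)C1`, which has not yet been measured. It carries quinolin-4-yl in place of isoquinolin-4-yl on a carbonyl carbon. The two groups have the same atoms, joined differently.

Among the compounds with values here, only one measured step touches this part of the molecule: a 2.2-fold lower number from compound 1 to compound 2 (0.33 log units; beyond the scatter). That step is modest, only just beyond the scatter, and it changes the atoms of the group rather than rearranging them. Compound 3 differs from compound 2 in more than one place, so it isolates no single change. Within the data shown here, no measured step swaps these two groups, so the data give no direction for the change. The expected result is no shift beyond the scatter, and the estimated step is a 1.1-fold higher number from compound 2 to compound 4 (0.03 log units; within the scatter). For compound 4 the expected value in this assay is 5.5 ug/mL, with an estimated range of 2.5 ug/mL to 12 ug/mL.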

Compound 4, solubility: 3.2 ug/mL
The estimate for compound 4 lay 1.7-fold (0.24 log units) above the measured number; measured number inside the range.
By their numbers in this assay, from the lowest: compounds 4, 3 and 2 (each within the scatter of the next); then compound 1.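

Within this assay, exchanging isoquinolin-4-yl for quinolin-4-yl on a carbonyl carbon, with the same atoms joined differently, gives a 1.6-fold lower number from compound 2 to compound 4 (0.20 log units; within the scatter), so this rearrangement produces no shift that can be told from the scatter. The group of compound 1, with its one oxygen and 11 heavy atoms, now stands apart from two different 10-atom groups rather than one: besides a 2.2-fold lower number from compound 1 to compound 2 (0.33 log units; beyond the scatter), there is also a 3.4-fold lower number from compound 1 to compound 4 (0.54 log units; beyond the scatter), and both steps lie beyond the scatter. No accompanying measurement offers an explanation for these numbers.

The compounds shown leave open whether other groups on this carbonyl carbon would stay within the scatter of compound 2 or reach the level of compound 1, for example naphthalen-1-yl, which has no ring nitrogen, or quinolin-4-yl bearing an amine. Within the data shown here, they also leave open whether the exchange of isoquinolin-4-yl for quinolin-4-yl would give a similar result if the rest of the molecule were changed, since only one pair of compounds isolates it.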